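Removing the piperazine ring: expected toxicity of compound 3

The source may report more compounds than this note shows. Statements on the series, on what has been measured and on what is new or still open speak of the compounds shown alone.

Measured so far in an ADME assay on HEK-293T cells (Homo sapiens) for cytotoxicity, read by CCK-8 assay, with a stated time of 24 h; on this read-out lower numbers stand for higher toxicity in this test and higher numbers for lower toxicity in this test:
compound 1 `Cc1ccc(NC(=O)c2ccc(C(F)(F)F)cc2)cc1-n1cc(-c2cnc3cccnn23)cn1`: > 80000 nM
compound 2 `Cc1ccc(NC(=O)c2ccc(CN3CCN(C)CC3)cc2)cc1-n1cc(-c2cnc3cccnn23)cn1`: 23800 nM

Compound 1 carries a trifluoromethyl group on its outer ring, and in this assay compound 1 returns only a limit, > 80000 nM. Compound 2 replaces that group with a (4-methylpiperazin-1-yl)methyl group, and in this assay compound 2 gives 23800 nM, the only number rather than a limit among the two results shown. Within the data shown here, the step of an at least 3.3-fold lower number from compound 1 to compound 2 (0.52 log units; beyond the scatter) is therefore the single measured step, and it is judged on a limit of > 80000 nM in this assay, at which 1 of the 2 values shown sits, at one end.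

Compound 3 `CCc1ccc(C(=O)Nc2ccc(C)c(-n3cc(-c4cnc5cccnn45)cn3)c2)cc1` is the compound not yet measured. Compared with compound 2, the change is methyl in place of 4-methylpiperazin-1-yl on a saturated chain carbon bound to an aromatic carbon, so the basic ring leaves and a plain ethyl chain remains. This undoes much of what separates compound 2 from compound 1, so the step from compound 1 to compound 2 is the one that bears on it, and its direction reversed is what is expected: a rise in the number, at least modest, estimated as a 2.5-fold higher number from compound 2 to compound 3 (0.40 log units; beyond the scatter). Compound 3 is thus expected to give about 60000 nM, in the range 25000 nM to 130000 nM.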

Compound 3, half-maximal cytotoxic concentration: > 80000 nM
Compound 3 ended at the assay's limit; the forecaster's own chance of this, stated with the estimate: 45%; middle value at least 1.3-fold (0.12 log units) away from the limit.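

In this assay, cutting the 4-methylpiperazin-1-yl group back to a methyl on the same saturated chain carbon gives an at least 3.3-fold higher number from compound 2 to compound 3 (0.52 log units; beyond the scatter), and this is a second step, from a different partner, in which the lower number goes with the (4-methylpiperazin-1-yl)methyl group. Compound 3 gives > 80000 nM, which is a limit of the assay and not a number. Compound 1 and compound 3 both end in limits, so the step between them cannot be read, yet the earlier single step can now be seen in a wider setting, with neither trifluoromethyl nor ethyl bringing the reading down to a number as the (4-methylpiperazin-1-yl)methyl group does: the limit of > 80000 nM in this assay, at which 2 of the 3 values shown sit.

The compounds shown leave open whether the whole ring is needed for the lower number, or whether a smaller amine such as dimethylamine on the same carbon, a morpholine ring or a piperazine without its methyl would give a similar reading. They also leave open how a carboxylic acid or a longer plain carbon chain at this place would read, and how far compound 1 and compound 3 lie beyond the end of the assay's range.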